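Exchanging the Aryl Tail of Compound 3

The compounds below may be only part of what the source reports. "The series", "measured", "known", "first", "only" and "open" are said of these compounds alone.

Of the compounds shown here, three built on a shared core have been measured in a functional assay with 5-hydroxytryptamine receptor 1B (Homo sapiens) as the target, read by radioligand binding and GTPgammaS binding; a lower number here means a smaller maximal response, a higher number a larger maximal response. Compound 1 `c1ccc(CC2CCN(CCCc3c[nH]c4ccc(-n5cnnc5)cc34)CC2)cc1` gives 62%. Within the data shown here, compound 2 `CN(Cc1ccccc1)C1CCN(CCCc2c[nH]c3ccc(-n4cnnc4)cc23)CC1` gives 77%, and the single measured step, a number 15 percentage points higher from compound 1 to compound 2 (beyond the scatter), is a modest one. Compound 3 `FC1(Cc2ccccc2C(F)(F)F)CCN(CCCc2c[nH]c3ccc(-n4cnnc4)cc23)CC1` gives 91%, the highest of the three numbers; the value of compound 2 and the value of compound 1 both lie well beneath it.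

Compound 4 `CC(CC1(F)CCN(CCCc2c[nH]c3ccc(-n4cnnc4)cc23)CC1)c1ccccc1` awaits measurement. It differs from compound 3 in one place: 1-phenylethyl in place of 2-(trifluoromethyl)phenyl on a saturated chain carbon bound to a saturated ring carbon. Among the measured compounds shown here, no measured step touches this position. For the measured compounds named here, the one step that is known concerns a different attachment on the ring, and it moved the maximal response by a modest amount, so it offers only a sense of scale, not of direction. Because compound 3 gives 91% and sits at the top of the set, a change at its tail is more likely to pull the number down than up. Compound 4 is therefore expected to reach about 78% in this assay, within a range of 60% to 95%. The estimated step is a number 13 percentage points lower from compound 3 to compound 4 (beyond the scatter).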

Compound 4, largest response reached (reported as efficacy), in percent of the reference or control that the assay uses: 85%
Estimate against measurement, compound 4: 7 percentage points below; measured number inside the range.
By their numbers in this assay, from the lowest: compound 1; then compounds 2, 4 and 3 (each within the scatter of the next, the first and the last beyond it).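

In this assay, exchanging 2-(trifluoromethyl)phenyl for 1-phenylethyl on a saturated chain carbon bound to a saturated ring carbon gives a number 6 percentage points lower from compound 3 to compound 4 (within the scatter) and so leaves the two compounds indistinguishable. Among these compounds, this is the first step read at this position, and it shows that a tail of carbon only, without the three fluorine atoms, can stand there with no change beyond the scatter. Nothing given here explains why the two tails read alike.

This single step shows nothing about how the maximal response would follow a tail carrying a carboxylic acid, a nitrile or a longer chain. As far as these compounds go, compound 3 and compound 4 also share the fluorine on the saturated ring carbon, so what that atom contributes remains open.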